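The compounds below may be only part of what the source reports. "The series", "measured", "known", "first", "only" and "open" are said of these compounds alone.

Compound 1 `Cc1nn(C)c(C)c1-c1ccc(-c2nnc(N(C)Cc3ccc4nccn4c3)o2)c(C#N)c1` differs from the rest in its core; in an assay on COS-7 cells for inhibition of tyrosine-protein kinase receptor UFO (Homo sapiens), read by ELISA, with a stated time of 1 h (on this read-out lower numbers stand for stronger inhibition and higher numbers for weaker inhibition), compound 1 returns only the assay limit > 31600 nM (the limit of > 31600 nM in this assay, at which 1 of the 3 values shown sits). Compound 2 `Cc1cc(-c2c(C)nn(C)c2C)cnc1-c1nnc(N(C)Cc2ccc3nccn3c2)o1`, on the core shared with the later compounds, gives 6310 nM in this assay. Among the compounds with values here, compound 3 `Cc1cc(-c2c(C)nn(C)c2C)cnc1-c1nnc(N(C)Cc2ccc3ncc(-c4cccc(CN(C)C)c4)n3c2)o1` gives 316 nM in this assay, the lowest number of the two measured values; the single measured step, a 20-fold lower number from compound 2 to compound 3 (1.30 log units; beyond the scatter), was large. Compound 4 `Cc1cc(-c2c(C)nn(C)c2C)cnc1-c1nnc(N(C)Cc2ccc3ncc(-c4ccc(CN(C)C)cn4)n3c2)o1` is next; the change is 5-((dimethylamino)methyl)pyridin-2-yl in place of 3-((dimethylamino)methyl)phenyl on an aromatic carbon. Within the data shown here, no measured step covers swapping one ring bearing a dimethylaminomethyl group for another, so the step of a 1.0-fold higher number from compound 3 to compound 4 (0.01 log units; within the scatter) is expected to stay within the scatter, without a clear direction. Compound 4 is therefore estimated at 320 nM, within 100 nM to 1000 nM.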

Compound 4, half-maximal inhibitory concentration in the tyrosine-protein kinase receptor UFO assay: 126 nM
For compound 4 the middle estimate is 2.5-fold (0.40 log units) above the measured one; measured number inside the range.
By their numbers in the tyrosine-protein kinase receptor UFO assay, from the lowest: compound 4; then compound 3; then compound 2. At a limit, above all of these: compound 1.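

In the tyrosine-protein kinase receptor UFO assay, the ring carrying the dimethylaminomethyl group on this aromatic carbon matters, not only the presence of the group: the swap to 5-((dimethylamino)methyl)pyridin-2-yl gives a 2.5-fold lower number from compound 3 to compound 4 (0.40 log units; beyond the scatter), and the same group in place of hydrogen gives a 50-fold lower number from compound 2 to compound 4 (1.70 log units; beyond the scatter). In a physicochemical assay for lipophilicity, at pH 7.4 (a higher number here means a more lipophilic compound, a lower number a more polar compound), compound 3 gives 3 and compound 4 gives 3. In the physicochemical assay, this ring swap shows no change at the digits printed from compound 3 to compound 4 (within the scatter). Nothing measured here accounts for the step. Still open, on these data alone, is whether a morpholine or a carboxylic acid in place of the dimethylamino group would keep these numbers on this ring.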